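The source may report more compounds than this note shows. Statements on the series, on what has been measured and on what is new or still open speak of the compounds shown alone.

Compounds measured so far:
compound 1 `O=C(CC1CCCCC1)N1CCN(c2nc(=O)c3cc(C(F)(F)F)cc([N+](=O)[O-])c3s2)CC1` gives 0.12 ug/mL
compound 2 `Cc1ccc(C(=O)N2CCN(c3nc(=O)c4cc(C(F)(F)F)cc([N+](=O)[O-])c4s3)CC2)cc1` gives 6.7 ug/mL
compound 3 `O=C(c1cccc(F)c1)N1CCN(c2nc(=O)c3cc(C(F)(F)F)cc([N+](=O)[O-])c3s2)CC1` gives 0.2 ug/mL

In a physicochemical assay for solubility, read by HPLC (a lower number here means a less soluble compound, a higher number a more soluble compound), compound 3 stands second highest of the three numbers, nearest to compound 1 and far from compound 2. The step of a 1.7-fold higher number from compound 1 to compound 3 (0.22 log units; within the scatter) lies within the scatter, whereas a 34-fold lower number from compound 2 to compound 3 (1.53 log units; beyond the scatter) is large, as is a 56-fold higher number from compound 1 to compound 2 (1.75 log units; beyond the scatter). Compound 4 `O=C(C1CCCC1)N1CCN(c2nc(=O)c3cc(C(F)(F)F)cc([N+](=O)[O-])c3s2)CC1` differs from compound 3 by cyclopentyl in place of 3-fluorophenyl on a carbonyl carbon. Within the data shown here, the step that bears most on this change is the one from compound 1, whose cyclohexylmethyl is likewise a saturated carbocycle, to compound 3, and that step was within the scatter. Compound 4 is therefore expected to sit close to compound 3 and compound 1, with a step of a 1.3-fold lower number from compound 3 to compound 4 (0.12 log units; within the scatter) not beyond the scatter. The estimate for compound 4 in this assay is 0.15 ug/mL, ranging from 0.05 ug/mL to 0.5 ug/mL.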

Compound 4, solubility: 5.34 ug/mL
For compound 4 the middle estimate is 36-fold (1.55 log units) below the measured one; the measured number lies above the stated range.
By their numbers in this assay, from the lowest: compounds 1 and 3 (each within the scatter of the next); then compounds 4 and 2 (each within the scatter of the next).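

In this assay cyclopentyl on this carbonyl carbon parts sharply from cyclohexylmethyl (a 45-fold higher number from compound 1 to compound 4 (1.65 log units; beyond the scatter)) and from 3-fluorophenyl (a 27-fold higher number from compound 3 to compound 4 (1.43 log units; beyond the scatter)), yet it stands level with 4-methylphenyl (a 1.3-fold lower number from compound 2 to compound 4 (0.10 log units; within the scatter)). The four compounds thus form two levels, and aromatic against non-aromatic does not sort them: compound 1 and compound 3 make up the lower level, compound 2 and compound 4 the upper, so each level holds one ring of either kind. Nothing measured here accounts for this split.

On these data alone, what a longer chain, or a phenyl ring carrying an amine, would give on this carbonyl carbon stays open, as does whether the two levels would persist with such groups.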